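The compounds below may be only part of what the source reports. "The series", "measured", "known", "first", "only" and "open" are said of these compounds alone.

Working notes. Compound 1 `CCOC(=O)c1cccc(-c2ccc(N(C)C)cc2)c1` and compound 2 `CCOc1ccc(-c2cccc(S(=O)(=O)N(C)C)c2)cc1` share a biaryl core. In an assay on COS-7 cells for inhibition of patatin-like phospholipase domain-containing protein 2 (Mus musculus), tested at 200 uM (a lower number here means less inhibition, a higher number more inhibition at the concentration tested (going by the name of the read-out)), compound 1 gives 87%, while compound 2 gives 63%, the lowest of the two numbers and a gap beyond the scatter. Compound 3 `CCOc1ccc(-c2cccc(C(=O)N3CCCC3)c2)cc1` is not yet measured; it differs from compound 2 by (pyrrolidin-1-yl)carbonyl in place of dimethylsulfamoyl on an aromatic carbon. Among the measured compounds shown here, with no measured step of this kind available, a modest rise in this assay is expected from compound 2 to compound 3 of a number 9 percentage points higher from compound 2 to compound 3 (within the scatter), since compound 1, also carrying a carbonyl, gives 87%. Compound 3 is therefore estimated at 72%, within 50% to 90%.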

Compound 3, a percentage reported as inhibition, at one concentration (the size of the read-out at that concentration, not a potency): 53%
Beside the measured number, compound 3's estimate is 19 percentage points above it; low and high end bracket the measured number.
By their numbers in this assay, from the lowest: compounds 3 and 2 (each within the scatter of the next); then compound 1.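

Within this assay, (pyrrolidin-1-yl)carbonyl in place of dimethylsulfamoyl on this aromatic carbon gives a number 10 percentage points lower from compound 2 to compound 3 (within the scatter), the first single-place step in the series. At this position, the two groups cannot be told apart in this read-out, and the swap to a carbonyl brings no rise. No supporting measurement bears on this result. The compounds shown leave open whether a carboxylic acid or a primary amine on this aromatic carbon would move the number beyond the scatter.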